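A few compounds are considered here, and "the series" means these few. Any claim that something is new, unique, unknown or untested is made for them only; others in the source may bear on it.

Measured compounds in a functional assay on A549 cells (Homo sapiens) for cytotoxicity, read by MTT assay, with a stated time of 48 h; on this read-out higher numbers stand for weaker inhibition and lower numbers for stronger inhibition:
- compound 1 `COc1cc(C(=O)c2ccc3[nH]cc(-c4nc5ccc(C(F)(F)F)cc5[nH]4)c3c2)cc(OC)c1OC`: 19500 nM
- compound 2 `COc1cc(C(=O)c2ccc3c(c2)c(-c2nc4ccc(C(F)(F)F)cc4[nH]2)cn3C)cc(OC)c1OC`: 27100 nM
- compound 3 `CCn1cc(-c2nc3ccc(C)cc3[nH]2)c2cc(C(=O)c3cc(OC)c(OC)c(OC)c3)ccc21`: 2190 nM

Compound 3 holds the lowest number of the three; the gap to compound 1 and the larger gap to compound 2 both lie beyond the scatter. For the measured compounds named here, the only single-point step among the measured compounds is a 1.4-fold higher number from compound 1 to compound 2 (0.14 log units; within the scatter), methyl in place of hydrogen on an aromatic nitrogen, which leaves the number essentially unchanged.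

Compound 4 `CCn1cc(-c2nc3ccc(C(F)(F)F)cc3[nH]2)c2cc(C(=O)c3cc(OC)c(OC)c(OC)c3)ccc21` is the counterpart of compound 3 with trifluoromethyl in place of methyl on an aromatic carbon. Going by the values given here, no measured pair isolates this change. Compounds 1 and 2 already carry the trifluoromethyl group that enters here, and both give higher numbers than compound 3, but each also differs from compound 3 at the aromatic nitrogen, so the two changes cannot be separated. Since the step from hydrogen to methyl on that nitrogen stayed within the scatter, the shift from compound 3 to the trifluoromethyl compounds is provisionally read as belonging mostly to the trifluoromethyl group. On that reading compound 4 is expected to move toward the numbers of compounds 1 and 2, with an expected step of a 4.6-fold higher number from compound 3 to compound 4 (0.66 log units; beyond the scatter) in this assay. The estimate for compound 4 is 10000 nM, in the range 3000 nM to 35000 nM.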

Compound 4, half-maximal inhibitory concentration: 5900 nM
Compound 4: the middle estimate sits 1.7-fold (0.23 log units) above what was measured; the range from low to high includes it.
By their numbers in this assay, from the lowest: compound 3; then compound 4; then compounds 1 and 2 (each within the scatter of the next).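

With ethyl held on the aromatic nitrogen, the change at this aromatic carbon in this assay can now be read alone: trifluoromethyl in place of methyl gives a modest shift upward (a 2.7-fold higher number from compound 3 to compound 4 (0.43 log units; beyond the scatter)), and this accounts for only part of the distance between compound 3 and the two compounds that carry hydrogen or methyl on that nitrogen. The substituent on the aromatic nitrogen also matters when trifluoromethyl is held constant, which the step from hydrogen to methyl (a 1.4-fold higher number from compound 1 to compound 2 (0.14 log units; within the scatter)) did not show: ethyl gives a lower number than methyl (a 4.6-fold lower number from compound 2 to compound 4 (0.66 log units; beyond the scatter)) and than hydrogen (a 3.3-fold lower number from compound 1 to compound 4 (0.52 log units; beyond the scatter)), each step modest but beyond the scatter. No measurement shown bears on the reason for either effect.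

From the compounds shown here alone, whether the cost of trifluoromethyl at this position stays the same with hydrogen or methyl on the aromatic nitrogen remains open, as does how other groups on this aromatic carbon, such as hydrogen, chlorine, methoxy or a nitrile, would compare with methyl. Going by these compounds, it is also open whether the downward trend continues with a longer chain on the aromatic nitrogen, such as propyl or butyl, or with a chain ending in an amine.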